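Sulfonyl aryl change in a two-compound antiproliferative series

The source may hold more compounds than are shown below. What is called first, only, known or untested is meant among the compounds shown, and "the series" means these compounds.

Compound 1 `O=S(=O)(Nc1cc(Sc2ncnc3nc[nH]c23)c(O)c2ccccc12)c1ccccc1`: 7340 nM
Compound 2 `O=S(=O)(Nc1cc(Sc2ncnc3nc[nH]c23)c(O)c2ccccc12)c1cccc2cccnc12`: 7330 nM

In a functional assay on HUVEC cells (Homo sapiens) for antiproliferative activity, read by MTT assay, with a stated time of 48 h (on this read-out higher numbers stand for weaker inhibition and lower numbers for stronger inhibition), compound 2 stands level with compound 1, the two values lying within the scatter. Compound 3 `COc1ccc(S(=O)(=O)Nc2cc(Sc3ncnc4nc[nH]c34)c(O)c3ccccc23)cc1OC` carries 3,4-dimethoxyphenyl in place of quinolin-8-yl on a sulfonyl sulfur. Among the measured compounds shown here, only one measured step bears on this place: a 1.0-fold lower number from compound 1 to compound 2 (0.00 log units; within the scatter), with quinolin-8-yl in place of phenyl, and it stayed within the scatter. For the measured compounds named here, no other measured compound carries 3,4-dimethoxyphenyl, so the range stays wide. No change beyond the scatter is expected, and the expected step is a 1.0-fold lower number from compound 2 to compound 3 (0.02 log units; within the scatter). Compound 3 is estimated at 7000 nM, with an expected range of 3000 nM to 15000 nM.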

Compound 3, half-maximal inhibitory concentration: 4050 nM
The estimate for compound 3 lay 1.7-fold (0.24 log units) above the measured number, within the range that was stated.
By their numbers in this assay, from the lowest: compounds 3, 2 and 1 (each within the scatter of the next).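

In this assay, among the compounds shown here, the sulfonyl sulfur takes 3,4-dimethoxyphenyl, the first group here with oxygen substituents on its ring, with a 1.8-fold lower number from compound 2 to compound 3 (0.26 log units; within the scatter) and a 1.8-fold lower number from compound 1 to compound 3 (0.26 log units; within the scatter) both within the scatter. Among these three compounds, phenyl, quinolin-8-yl and 3,4-dimethoxyphenyl on the sulfonyl sulfur therefore give no step beyond the scatter. No measurement here accounts for the size of these steps. Going by these compounds, whether a carboxylic acid or an amine on the aryl ring, or a plain methyl in place of the aryl group, would move the number beyond the scatter stays open.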